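Iodo in place of bromo: working notes on compound 4

The source may report more compounds than this note shows. Statements on the series, on what has been measured and on what is new or still open speak of the compounds shown alone.

In a functional assay on FM3A cells (Mus musculus) for antiproliferative activity, with a stated time of 48 h (on this read-out lower numbers stand for stronger inhibition and higher numbers for weaker inhibition), compound 1 `Nc1ccc(/C=C/C(=O)c2ccccc2)cc1` gives 146000 nM, compound 2 `Nc1ccc(/C=C/C(=O)c2ccc(F)cc2)cc1` gives 185000 nM and compound 3 `Nc1ccc(/C=C/C(=O)c2ccc(Br)cc2)cc1` gives 120000 nM. Compound 3 therefore stands within the scatter of both other compounds. Compound 4 `Nc1ccc(/C=C/C(=O)c2ccc(I)cc2)cc1` follows from compound 3 through (iodo in place of bromo on an aromatic carbon), iodo in place of bromo on an aromatic carbon, para to a large group. The relevant measured steps are bromo for hydrogen, a 1.2-fold lower number from compound 1 to compound 3 (0.09 log units; within the scatter), bromo for fluoro, a 1.5-fold lower number from compound 2 to compound 3 (0.19 log units; within the scatter), and fluoro for hydrogen, a 1.3-fold higher number from compound 1 to compound 2 (0.10 log units; within the scatter). All three remain within the scatter, so no step beyond it is expected in this assay. The expected step is a 1.0-fold lower number from compound 3 to compound 4 (0.02 log units; within the scatter). Compound 4 is estimated at 115000 nM, with an expected range of 70000 nM to 190000 nM.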

Compound 4, half-maximal inhibitory concentration: 110000 nM
Compound 4: middle estimate off by 1.0-fold (0.02 log units), on the high side; the measured number falls inside the stated range.
By their numbers in this assay, from the lowest: compounds 4, 3, 1 and 2 (each within the scatter of the next).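

In this assay iodo on this aromatic carbon, para to a large group, stays within the scatter of every earlier compound: iodo for bromo gives a 1.1-fold lower number from compound 3 to compound 4 (0.04 log units; within the scatter) and iodo for hydrogen gives a 1.3-fold lower number from compound 1 to compound 4 (0.12 log units; within the scatter) and iodo for fluoro gives a 1.7-fold lower number from compound 2 to compound 4 (0.23 log units; within the scatter) on the same read-out. With iodo added, hydrogen, fluoro, bromo and iodo at this position are still not separated, so this change opens no step beyond the scatter.

From the compounds shown here alone, whether a carboxylic acid, an amine or a longer chain here would move the number beyond the scatter stays open. The reason for this flat result also stays open, as nothing available bears on it.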